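The source may hold more compounds than are shown below. What is called first, only, known or untested is meant among the compounds shown, and "the series" means these compounds.

Compound 1 `O=C(C1=C(O)C(=O)N(CCCn2ccnc2)C1c1ccc(Br)cc1)c1ccccc1` — in a functional assay on U2OS cells (Homo sapiens) for antiproliferative activity, read by MTT assay, with a stated time of 72 h (a higher number here means a weaker inhibitor, a lower number a stronger inhibitor), compound 1 gives "not active" (no number reported).
Compound 2 `O=C(C1=C(Nc2ccc(I)cc2)C(=O)N(CCCn2ccnc2)C1c1ccc(Br)cc1)c1ccccc1` — in this assay compound 2 gives 12000 nM.
Compound 3 `O=C(C1=C(Nc2ccc(Cl)cc2)C(=O)N(CCCn2ccnc2)C1c1ccc(Br)cc1)c1ccccc1` — in this assay compound 3 gives 22800 nM.

All three share one core; they differ only in the group attached to the carbon that in compound 1 carries a hydroxyl. Among the compounds with values here, compound 3 cannot be placed apart from compound 2, since the one measured step of a 1.9-fold higher number from compound 2 to compound 3 (0.28 log units; within the scatter) lies within the scatter; compound 1, which lacks the arylamino group altogether, gives no number at all.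

Compound 4 `O=C(C1=C(NCc2ccccc2)C(=O)N(CCCn2ccnc2)C1c1ccc(Br)cc1)c1ccccc1` carries the change (benzyl in place of 4-chlorophenyl on an amine nitrogen). Within the data shown here, the only measured step, a 1.9-fold higher number from compound 2 to compound 3 (0.28 log units; within the scatter), swaps one halogen for another on the aromatic ring of the arylamino group and changes nothing beyond the scatter; no measured step replaces that aromatic ring with a benzyl group, so the expectation for this change rests on thin ground. Compound 1 shows that removing the arylamino group entirely costs all measurable activity, whereas compound 4 keeps an amine with an aromatic ring nearby. The step of a 1.1-fold higher number from compound 3 to compound 4 (0.04 log units; within the scatter) is therefore expected to be modest. Compound 4 is estimated at 25000 nM, with a range from 8000 nM to 80000 nM.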

Compound 4, half-maximal inhibitory concentration: 32500 nM
Beside the measured number, compound 4's estimate is 1.3-fold (0.11 log units) below it; the range from low to high includes it.
By their numbers in this assay, from the lowest: compounds 2, 3 and 4 (each within the scatter of the next, the first and the last beyond it).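

On the amine nitrogen, benzyl can take the place of 4-chlorophenyl with no change that can be told apart in this assay, since the step is a 1.4-fold higher number from compound 3 to compound 4 (0.15 log units; within the scatter) and so adds a second kind of group to those that give a number here, whereas compound 1, which has a hydroxyl in place of the whole amine, gives "not active" (no number reported). Set against the 4-iodophenyl group, however, benzyl gives the only step so far that leaves the scatter, a 2.7-fold higher number from compound 2 to compound 4 (0.43 log units; beyond the scatter), so compound 2 and compound 4 can be told apart even though compound 3 cannot be separated from either. Nothing measured here gives a reason for these small steps.

The compounds shown leave open whether an aromatic ring is needed on this amine at all, which a cyclohexyl group would test, and whether a longer chain such as 2-phenylethyl would keep a number. They also leave open what iodo, chloro or a carboxylic acid on the ring of the benzyl group would do.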